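This account rests on a few compounds, and the source may have more. Where it says the series, first, only, none or still open, it means among the compounds named here.

Compound 1 `O=[N+]([O-])c1ccc(COc2ccc(Nc3ncnc4cc5c(cc34)OCCOCCO5)cc2)cc1` was tested in a functional assay on HepG2 cells (Homo sapiens) for antiproliferative activity, read by MTT assay, with a stated time of 72 h (on this read-out lower numbers stand for stronger inhibition and higher numbers for weaker inhibition), and gave only a limit, > 100000 nM. Compound 2 `FC(F)(F)c1ccc(COc2ccccc2Nc2ncnc3cc4c(cc23)OCCOCCO4)cc1` likewise reached only a limit in this assay, > 100000 nM. Within the data shown here, compound 1 thus stands at the edge of the assay, because both values sit at the limit of > 100000 nM in this assay, at which 2 of the 2 values shown sit, and no measured step between compounds exists. Compound 3 `c1ccc(COc2ccc(Nc3ncnc4cc5c(cc34)OCCOCCO5)cc2)cc1` differs from compound 1 by hydrogen in place of nitro on an aromatic carbon. Among the measured compounds shown here, with no measured step of this kind, the expected step from compound 1 to compound 3 is none beyond the scatter, a number no higher from compound 1 to compound 3 (the limit leaves the size open). Compound 3 is therefore estimated at 100000 nM, between 30000 nM and 300000 nM, most likely again only a limit.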

Compound 3, half-maximal inhibitory concentration: 55500 nM
Compound 3: middle estimate off by 1.8-fold (0.26 log units), on the high side; the range from low to high includes it.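

In this assay, the change from 4-nitrobenzyl to benzyl gives an at least 1.8-fold lower number from compound 1 to compound 3 (0.25 log units; that floor lies within the scatter). Among these compounds, compound 3 is the first compound here to give a measured number rather than a limit, so with hydrogen at this position the read-out falls within the range of the assay. Going by these compounds, the step is only a floor, and its true size stays open: the limit of > 100000 nM in this assay, at which 2 of the 3 values shown sit. The compounds shown leave open whether an amine or a methoxy group at this position would give a number different from that of compound 3. They also leave open how a longer chain in place of benzyl would read.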